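Cytotoxicity limits across three analogues and a new one

The compounds below may be only part of what the source reports. "The series", "measured", "known", "first", "only" and "open" are said of these compounds alone.

Measured in an ADME assay on BJ cells (Homo sapiens) for cytotoxicity, with a stated time of 72 h; a lower number here means that less compound is needed, a higher number that more compound is needed for the effect:
compound 1 `COc1ccc(-c2nc3c(c(C)nn3-c3ccccc3)c(-c3ccccc3O)c2C#N)cc1` — > 23000 nM
compound 2 `CCc1ccc(-c2nc3c(c(C)nn3-c3ccccc3)c(-c3ccccc3OC(F)(F)F)c2C#N)cc1` — > 20000 nM
compound 3 `CCc1ccc(-c2nc3c(c(C)nn3-c3ccccc3)c(-c3ccc(O)cc3)c2C#N)cc1` — > 20000 nM

Compound 1 stands at a limit of this assay, not at a number, with > 23000 nM. Compound 2 also sits at a limit, > 20000 nM. Compound 3 likewise sits at a limit, > 20000 nM. For the measured compounds named here, the only step between measured compounds, a step that the two limits leave unreadable from compound 2 to compound 3, is therefore unreadable; all three values rest on the limit of > 20000 nM in this assay, at which 2 of the 3 values shown sit, or (the limit of > 23000 nM in this assay, at which 1 of the 3 values shown sits).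

Compound 4 `CCc1cccc(-c2nc3c(c(C)nn3-c3ccccc3)c(-c3ccccc3O)c2C#N)c1` arises from compound 1 by 3-ethylphenyl in place of 4-methoxyphenyl on an aromatic carbon. Going by the values given here, no measured step bears on this change, so no shift beyond the scatter is expected, and compound 4 is estimated at 25000 nM, within 10000 nM to 60000 nM. The expected step is a step that the limit leaves unreadable from compound 1 to compound 4.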

Compound 4, half-maximal effective concentration: > 20000 nM
Compound 4: no number, only a limit; the forecaster's own chance of this, stated with the estimate: 80%; the middle value is on the limit's open side.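

For the compounds shown here, compound 1 and compound 4 both stand at limits, not numbers, and no step between them can be read. The compounds shown leave open at what concentration any of the four reaches its effect in this assay, and whether 3-ethylphenyl in place of 4-methoxyphenyl changes that concentration.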